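Adding one methyl to compound 2

The source may report more compounds than this note shows. Statements on the series, on what has been measured and on what is new or still open speak of the compounds shown alone.

Measured in a functional assay on HeLa cells (Homo sapiens) for antiproliferative activity, read by MTT assay, with a stated time of 48 h; on this read-out higher numbers stand for weaker inhibition and lower numbers for stronger inhibition:
compound 1 `Cc1cc2nc(-c3cn(-c4ccccc4)nc3-c3ccccc3)[nH]c2cc1C`: 41500 nM
compound 2 `Cc1ccc2[nH]c(-c3cn(-c4ccccc4)nc3-c3ccc(Cl)cc3)nc2c1`: 5360 nM

Compound 2, at 5360 nM, holds the lower of the two numbers, while compound 1, at 41500 nM, lies higher by more than the usual scatter. Compound 3 `Cc1cc2nc(-c3cn(-c4ccccc4)nc3-c3ccc(Cl)cc3)[nH]c2cc1C` differs from compound 2 by one change: methyl in place of hydrogen on an aromatic carbon. Among the compounds with values here, no measured pair shows this change alone. In this assay, no step beyond the scatter is expected. The estimated change is a 1.1-fold higher number from compound 2 to compound 3 (0.05 log units; within the scatter). Compound 3 is expected at 6000 nM, within an estimated range of 2200 nM to 16000 nM.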

Compound 3, half-maximal inhibitory concentration: 21800 nM
Beside the measured number, compound 3's estimate is 3.6-fold (0.56 log units) below it; the whole stated range lies below it.
By their numbers in this assay, from the lowest: compound 2; then compounds 3 and 1 (each within the scatter of the next).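

In this assay, the added methyl on the aromatic carbon ortho to a methyl group gives a 4.1-fold higher number from compound 2 to compound 3 (0.61 log units; beyond the scatter), so this position does not tolerate the change silently. The pair of compound 1 and compound 3 isolates the chloro change, and a 1.9-fold lower number from compound 1 to compound 3 (0.28 log units; within the scatter) stays inside the usual scatter. Of the two differences between compound 1 and compound 2, only the methyl step is therefore resolved on its own.

As far as these compounds go, whether an ethyl group or an amine on this aromatic carbon would act like methyl remains open. Nothing available explains the step.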